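Dropping One Phenyl Group on Two Related Cores

The source may hold more compounds than are shown below. What is called first, only, known or untested is meant among the compounds shown, and "the series" means these compounds.

Compound 1 `CCCCCCCN(CCCCCSc1cc(-c2ccccc2)c(-c2ccccc2)nn1)C(=O)Nc1ccc(F)cc1F` and compound 3 `CCCCCCCN(CCCCCS(=O)(=O)c1cc(-c2ccccc2)c(-c2ccccc2)nn1)C(=O)Nc1ccc(F)cc1F` differ in more than one place; the difference between their two cores is not broken down here. In an assay on microsomes from liver for inhibition of sterol O-acyltransferase 1 (Rattus norvegicus), tested at 50 ug/mL (on this read-out lower numbers stand for less inhibition and higher numbers for more inhibition at the one concentration tested (going by the name of the read-out)), compound 1 gives 75% and compound 3 gives 70%, within the scatter of each other. Compound 2 `CCCCCCCN(CCCCCSc1ccc(-c2ccccc2)nn1)C(=O)Nc1ccc(F)cc1F` carries the change hydrogen in place of phenyl on an aromatic carbon relative to compound 1, and in this assay compound 2 gives 44%, a step of a number 31 percentage points lower from compound 1 to compound 2 (beyond the scatter). Compound 4 `CCCCCCCN(CCCCCS(=O)(=O)c1cc(-c2ccccc2)cnn1)C(=O)Nc1ccc(F)cc1F` stands to compound 3 as compound 2 stands to compound 1: hydrogen in place of phenyl on an aromatic carbon. It is the same kind of change, though the place differs: in compound 4 the carbon lies next to the ring nitrogen and para to a large group, whereas in compound 2 it lies meta to a large group and opposite the ring nitrogen. For compound 4 the expected step in this assay is a number 28 percentage points lower from compound 3 to compound 4 (beyond the scatter), resting on the drop in a number 31 percentage points lower from compound 1 to compound 2 (beyond the scatter). Compound 4 is therefore estimated at 42%, likely between 25% and 60%.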

Compound 4, a percentage reported as inhibition, at one concentration (the size of the read-out at that concentration, not a potency): 67%
The estimate for compound 4 lay 25 percentage points below the measured number; measured number outside the range, above it.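

In this assay, hydrogen in place of phenyl on an aromatic carbon gave a number 3 percentage points lower from compound 3 to compound 4 (within the scatter), so the large loss seen on the core of compound 1 did not recur on the core of compound 3. The same change therefore cannot be carried from one core to the other at a fixed size: the same change on two cores in this assay, a number 31 percentage points lower (beyond the scatter) from compound 1 to compound 2 and a number 3 percentage points lower (within the scatter) from compound 3 to compound 4, 28 percentage points apart, beyond the scatter of two such steps. These two pairs do not show which difference between the cores accounts for this, and the phenyl group also leaves from a different place in each pair, so they give no rule for other cores.

From the compounds shown here alone, it remains open how a methyl group or an amine in place of that phenyl group would fare on either core. Going by these compounds, the effect of a longer linking chain also remains open.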